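Working notes: step from compound 3 to compound 4

A few compounds are considered here, and "the series" means these few. Any claim that something is new, unique, unknown or untested is made for them only; others in the source may bear on it.

Measured so far in a functional assay on cells for antagonist activity at Free fatty acid receptor 1 (Homo sapiens), read by TR-FRET and inositol phosphate accumulation, with a stated time of 2 h; on this read-out lower numbers stand for stronger inhibition and higher numbers for weaker inhibition:
compound 1 `Cc1cc(COc2ccc(Cl)cc2)nc(-c2ccccn2)n1`: 251 nM
compound 2 `Cc1cc(COc2ccccc2F)nc(-c2ccccn2)n1`: 398 nM
compound 3 `Fc1ccc(OCc2cc(N3CC4(CCO4)C3)nc(-c3ccccn3)n2)c(F)c1F`: 501 nM

Compound 3 sits within the scatter of both compound 1 and compound 2 in this assay, so the three measured compounds are not separated from one another. Going by the values given here, the only single-point step measured, a 1.6-fold higher number from compound 1 to compound 2 (0.20 log units; within the scatter), concerns the aryl ether and does not touch the position changed next. Compound 4 `Fc1ccc(OCc2cc(OCC3CCC3)nc(-c3ccccn3)n2)c(F)c1F` differs from compound 3 by a group of 6 heavy atoms (5 carbon, 1 oxygen; one four-membered non-aromatic ring of carbon only) in place of a group of 7 heavy atoms (5 carbon, 1 nitrogen, 1 oxygen; 2 four-membered non-aromatic rings with 1 hetero atom each), on an aromatic carbon. Among the compounds with values here, no measured step bears on this change, so nothing argues for a shift beyond the scatter in either direction. The expected step is therefore a 1.0-fold lower number from compound 3 to compound 4 (0.00 log units; within the scatter), no more than the scatter. The estimate for compound 4 in this assay is 500 nM, with a range from 180 nM to 1400 nM.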

Compound 4, half-maximal inhibitory concentration: 12.6 nM
Compound 4: the middle estimate sits 40-fold (1.60 log units) above what was measured, and the stated range ends above it.
By their numbers in this assay, from the lowest: compound 4; then compounds 1, 2 and 3 (each within the scatter of the next).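

Cyclobutylmethoxy in place of the group of 7 heavy atoms gives a 40-fold lower number from compound 3 to compound 4 (1.60 log units; beyond the scatter) in this assay, the first step in the series beyond the scatter. This aromatic carbon therefore responds strongly to the group it carries, whereas the aryl ether step, a 1.6-fold higher number from compound 1 to compound 2 (0.20 log units; within the scatter), stayed within the scatter. No available evidence bears on what lies behind the step.

The compounds shown leave open whether the lower number follows the carbocyclic ring or the ether oxygen on the aromatic carbon. A cyclobutylmethylamino group or a plain methoxy group at this carbon would separate the two.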